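This account rests on a few compounds, and the source may have more. Where it says the series, first, only, none or still open, it means among the compounds named here.

Compound 3, `Oc1cccc(-c2cc(-c3ccco3)cc(-c3ccccc3O)n2)c1`, was tested in an assay on isolated protein for inhibition of DNA topoisomerase 1 (Homo sapiens), with a stated time of 30 min, tested at 20 uM (on this read-out higher numbers stand for a stronger effect at the one concentration tested and lower numbers for a weaker effect), where compound 3 gives 0%. Its nearest measured relative is compound 1, `Oc1cccc(-c2cc(-c3cccs3)cc(-c3ccccc3O)n2)c1`, which in this assay gives 1.5%. Going by the values given here, the single measured step between these two, a number 1.5 percentage points lower from compound 1 to compound 3 (within the scatter), lies inside the scatter, so compound 3 sits together with compound 1 at essentially no inhibition, and neither can be called weaker or stronger than the other. A third member of the set, compound 2, `Oc1cccc(-c2cc(-c3ccsc3)cc(-c3ccccc3O)n2)c1`, is a close relative of compound 1, but for compound 2 the result in this assay is "not determined" (no result reported), so it adds nothing to the comparison.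

Compound 4, `Oc1ccc(-c2cc(-c3ccco3)cc(-c3cccc(O)c3)n2)cc1`, is the compound still to be measured. It differs from compound 3 by 4-hydroxyphenyl in place of 2-hydroxyphenyl on an aromatic carbon: the 2-hydroxyphenyl group next to the ring nitrogen of the shared core leaves, and a 4-hydroxyphenyl group enters there, the same atoms joined differently. Among the compounds with values here, no measured step touches this kind of change. Within the data shown here, the only step in hand, a number 1.5 percentage points lower from compound 1 to compound 3 (within the scatter), alters the furan-2-yl and thiophen-2-yl group instead, and it is itself within the scatter. With both measured numbers near zero and no sign of movement, no step beyond the scatter is expected in this assay.

Compound 4 is therefore expected in this assay to give about 2%, within a range from 0% to 12%. The expected step is a number 2 percentage points higher from compound 3 to compound 4 (within the scatter), which stays within the scatter.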

Compound 4, a percentage reported as inhibition, at one concentration (the size of the read-out at that concentration, not a potency): 1.5%
The estimate for compound 4 lay 0.5 percentage points above the measured number; the range from low to high includes it.
By their numbers in this assay, from the lowest: compounds 3, 1 and 4 (each within the scatter of the next).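

In this assay, going by these compounds alone, the earlier step changed only the furan-2-yl and thiophen-2-yl group, whereas this one gives the first reading at the place next to the ring nitrogen: 4-hydroxyphenyl in place of 2-hydroxyphenyl gives a number 1.5 percentage points higher from compound 3 to compound 4 (within the scatter). The group that leaves and the group that enters have the same atoms and the same counts of hydrogen-bond donors and acceptors, so the change only moves the hydroxyl group around the phenyl ring, and for this one pair that move does not lift the read-out out of the scatter. Nothing available gives any reason for this flat result.

With every number so far close to zero at the one concentration tested, the compounds shown cannot tell whether this place matters for inhibition at all, since a change that makes no difference here might still matter in a compound with real activity. They also leave open whether a different group at this place, such as a phenyl ring carrying an amine or a carboxylic acid instead of the hydroxyl group, would move the number beyond the scatter.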